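Exchanging the Aryl Group on a Shared Hydrazone Core

The source may report more compounds than this note shows. Statements on the series, on what has been measured and on what is new or still open speak of the compounds shown alone.

Compound 1 `Cn1c(=O)c(=O)n(C2CCCC2)c2nc(N/N=C/c3ccc(Cl)cc3)ncc21` gives 9810 nM in a functional assay on HCT-116 cells (Homo sapiens) for antiproliferative activity, read by MTT assay; on this read-out higher numbers stand for weaker inhibition and lower numbers for stronger inhibition.
Compound 2 `COc1cccc(/C=N/Nc2ncc3c(n2)n(C2CCCC2)c(=O)c(=O)n3C)c1` gives 45800 nM.
Compound 3 `Cn1c(=O)c(=O)n(C2CCCC2)c2nc(N/N=C/c3ccc(F)cc3Cl)ncc21` gives 13800 nM.

Compound 3 stands second highest of the three numbers; the step that reaches it from its nearest neighbour lies within the scatter (a 1.4-fold higher number from compound 1 to compound 3 (0.15 log units; within the scatter)), and the step that reaches it from its furthest neighbour lies beyond it (a 3.3-fold lower number from compound 2 to compound 3 (0.52 log units; beyond the scatter)). Compound 4 `Cn1c(=O)c(=O)n(C2CCCC2)c2nc(N/N=C/c3cc([N+](=O)[O-])ccc3Cl)ncc21` has not yet been measured. It differs from compound 3 in one place: 2-chloro-5-nitrophenyl in place of 2-chloro-4-fluorophenyl on a carbon with a double bond to nitrogen. All measured steps exchange the same aryl group and are at most modest: a 4.7-fold higher number from compound 1 to compound 2 (0.67 log units; beyond the scatter) and a 3.3-fold lower number from compound 2 to compound 3 (0.52 log units; beyond the scatter) lie beyond the scatter, while a 1.4-fold higher number from compound 1 to compound 3 (0.15 log units; within the scatter) lies within it. For the measured compounds named here, a 2-chloro-5-nitrophenyl group does not appear among the measured compounds, so no step bears on it directly. The expected step is small, a 1.1-fold higher number from compound 3 to compound 4 (0.04 log units; within the scatter), and compound 4 is estimated at 15000 nM, within a range from 5000 nM to 45000 nM.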

Compound 4, half-maximal inhibitory concentration: 5610 nM
Compound 4: the middle estimate sits 2.7-fold (0.43 log units) above what was measured; low and high end bracket the measured number.
By their numbers in this assay, from the lowest: compounds 4, 1 and 3 (each within the scatter of the next, the first and the last beyond it); then compound 2.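

With the 2-chloro part kept, exchanging only the other group on the ring still moves the result beyond the scatter, a 2.5-fold lower number from compound 3 to compound 4 (0.39 log units; beyond the scatter). The larger 2-chloro-5-nitrophenyl group also stays within the scatter of 4-chlorophenyl, a 1.7-fold lower number from compound 1 to compound 4 (0.24 log units; within the scatter), and widens the distance from 3-methoxyphenyl, an 8.2-fold lower number from compound 2 to compound 4 (0.91 log units; beyond the scatter). Nothing measured here gives a reason for these steps. On these data alone, it remains open whether an amine or a carboxylic acid in place of the nitro group would give a similar number. The compounds shown also leave open how changes elsewhere on the shared core would act.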